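The compounds below may be only part of what the source reports. "The series", "measured", "known", "first", "only" and "open" are said of these compounds alone.

In a functional assay on KB403 cells (Homo sapiens) for cytotoxicity, read by MTT assay, with stated times of 6 h and 48 h (on this read-out higher numbers stand for weaker inhibition and lower numbers for stronger inhibition), compound 1 (`Cn1c(/C=C/C(=O)c2ccccc2)cc(Br)c1Br`) gives >= 100000 nM, which is a limit of the assay and not a number. Its place on the scale is therefore known only as the limit of >= 100000 nM in this assay, at which 1 of the 2 values shown sits. Compound 2 (`Cn1c(/C=C/C(=O)c2ccc[nH]2)cc(Br)c1Br`), which has 1H-pyrrol-2-yl in place of phenyl on a carbonyl carbon, gives 600 nM. Going by the values given here, this is the only measured step, an at least 160-fold lower number from compound 1 to compound 2 (2.22 log units; beyond the scatter). Compound 3 (`Cn1c(/C=C/C(=O)c2cccc(O)c2)cc(Br)c1Br`) keeps the phenyl group of compound 1 and changes it in one place: hydroxy in place of hydrogen on an aromatic carbon, with hydroxy in place of hydrogen on an aromatic carbon, meta to a large group. The measured step bears on this change only in part, since it replaced the whole group on the carbonyl carbon, while compound 3 differs by a single substituent on that group. A shift in the same direction is therefore expected, but a smaller one than an at least 160-fold lower number from compound 1 to compound 2 (2.22 log units; beyond the scatter), and it may not clear the limit of the assay. The expected change in this assay is an estimated at least 5.0-fold lower number from compound 1 to compound 3 (0.69 log units; beyond the scatter). Compound 3 is estimated at 20000 nM, with an expected range of 2500 nM to 100000 nM.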

Compound 3, half-maximal inhibitory concentration: >= 100000 nM
Compound 3 gave a limit, no number; the forecaster's own chance of this, stated with the estimate: 35%; at least 5.0-fold (0.69 log units) between middle value and limit.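

In this assay, compound 3 stands at a limit of the assay, as compound 1 does, so no step between compound 1 and compound 3 can be read: the limit of >= 100000 nM in this assay, at which 2 of the 3 values shown sit.

The compounds shown leave open how far past that limit each compound lies, and whether hydroxy in place of hydrogen on an aromatic carbon changes the number at all.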